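The source may hold more compounds than are shown below. What is called first, only, known or untested is meant among the compounds shown, and "the series" means these compounds.

Measured compounds:
Compound 1 `CSCC[C@H](NC(=O)[C@H](CC(C)C)NC(=O)[C@H](CO)NC(=O)CC[C@H](NS(=O)(=O)c1ccc(Cl)c(C(F)(F)F)c1)C(=O)O)C(N)=O` gives 5700 nM in an assay on isolated protein for inhibition of Matrilysin (Homo sapiens), read by fluorescence, with a stated time of 15 min; on this read-out lower numbers stand for stronger inhibition and higher numbers for weaker inhibition.
Compound 2 `CSCC[C@H](NC(=O)[C@H](CC(C)C)NC(=O)[C@H](C)NC(=O)C[C@H](NS(=O)(=O)c1ccc(Cl)c(C(F)(F)F)c1)C(=O)O)C(N)=O` gives 4700 nM in this assay.

On the numbers shown, compound 1 holds the highest value of the two, and its nearest neighbour is compound 2, which sits within the scatter of compound 1; on these two values alone no order between them can be claimed, and since the two structures differ in more than one place, no single step is counted between them.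

The unmeasured compound 3 `CSCC[C@H](NC(=O)[C@H](CC(C)C)NC(=O)[C@H](C)NC(=O)CC[C@H](NS(=O)(=O)c1ccc(Cl)c(C(F)(F)F)c1)C(=O)O)C(N)=O` differs from compound 1 by one change: hydrogen in place of hydroxy on a saturated chain carbon, two bonds along the chain from an amide-type nitrogen and a carbonyl carbon. The rest of the molecule, including the sulfonamide-bearing acid, the longer chain and the terminal amide, is kept. Within the data shown here, no measured pair isolates this change, so its effect on this assay is unknown; with both measured compounds lying within the scatter of each other, a step of modest size in either direction, or none beyond the scatter, is what one would expect.

Compound 3 is therefore estimated at 5000 nM, within 2200 nM to 11000 nM, an expected step of a 1.1-fold lower number from compound 1 to compound 3 (0.06 log units; within the scatter).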

Compound 3, half-maximal inhibitory concentration: 440 nM
Compound 3: the middle estimate sits 11-fold (1.06 log units) above what was measured, outside the stated range (below it).
By their numbers in this assay, from the lowest: compound 3; then compounds 2 and 1 (each within the scatter of the next).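

In this assay, the change from hydroxymethyl to methyl on a saturated chain carbon, two bonds along the chain from an amide-type nitrogen and a carbonyl carbon, gives a 13-fold lower number from compound 1 to compound 3 (1.11 log units; beyond the scatter). Among these compounds, this is the first sign that this position matters: the two earlier compounds lay within the scatter of each other and differed in more than one place, so they could not show the effect of this group alone. With the rest of the molecule kept, a hydrogen in place of one hydroxy is enough for a large step, but no measurement shown here offers an explanation for its size.

The compounds shown leave open whether the step belongs to the hydroxy alone or whether other groups at this carbon, such as an ethyl, a methoxymethyl or an aminomethyl, would fall near compound 1 or near compound 3. They also leave open whether the same change would give a step of similar size on the shorter chain of compound 2, or with another group in place of the chloro and trifluoromethyl substituents on the sulfonamide.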